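The source may hold more compounds than are shown below. What is called first, only, known or untested is meant among the compounds shown, and "the series" means these compounds.

Measured compounds in a functional assay on RXF 393 cells (Homo sapiens) for inhibition, read by sulforhodamine B assay, with a stated time of 48 h; a higher number here means a weaker inhibitor of growth, a lower number a stronger inhibitor of growth:
compound 1 `CC(=O)/C(=C\c1c(-c2ccccc2)[nH]c2ccccc12)S(=O)(=O)c1ccccc1` — 1300 nM
compound 2 `O=C(/C(=C\c1c(-c2ccccc2)[nH]c2ccccc12)S(=O)(=O)c1ccccc1)c1ccccc1` — 97100 nM
compound 3 `N#C/C(=C\c1c(-c2ccccc2)[nH]c2ccccc12)S(=O)(=O)c1ccccc1` — 3600 nM

Compound 3 holds the second highest of the three numbers in this assay. Its nearest neighbour is compound 1, from which it differs by a 2.8-fold higher number from compound 1 to compound 3 (0.44 log units; beyond the scatter); its furthest is compound 2, with a 27-fold lower number from compound 2 to compound 3 (1.43 log units; beyond the scatter) on the way from compound 2 to compound 3.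

Compound 4 `N#C/C(=C\c1c(-c2ccccc2)[nH]c2ccccc12)C(=O)c1ccccc1` is not yet measured. It differs from compound 3 by benzoyl in place of phenylsulfonyl on a double-bonded chain carbon bound to a double-bonded chain carbon and a triple-bonded carbon. Within the data shown here, no measured pair shows this exact swap. Among the measured compounds shown here, two steps bear on it indirectly: a benzoyl entering in place of methyl on the carbonyl carbon gave a 75-fold higher number from compound 1 to compound 2 (1.87 log units; beyond the scatter), and removal of benzoyl in favour of cyano gave a 27-fold lower number from compound 2 to compound 3 (1.43 log units; beyond the scatter). Both times the compound carrying benzoyl had the higher number, and by a wide margin. Compound 4 carries benzoyl, so a step toward a higher number in this assay, beyond the scatter and likely large, is expected, with a 6.9-fold higher number from compound 3 to compound 4 (0.84 log units; beyond the scatter) the estimated size. Compound 4 is accordingly estimated at 25000 nM, within a range of 6000 nM to 100000 nM.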

Compound 4, concentration for 50% growth inhibition: 9600 nM
The estimate for compound 4 lay 2.6-fold (0.42 log units) above the measured number; measured number inside the range.
By their numbers in this assay, from the lowest: compound 1; then compound 3; then compound 4; then compound 2.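

In this assay, among these compounds, the phenylsulfonyl group is exchanged for the first time, and benzoyl in its place on the double-bonded chain carbon bound to a double-bonded chain carbon and a triple-bonded carbon gives a modest change (a 2.7-fold higher number from compound 3 to compound 4 (0.43 log units; beyond the scatter)). The sulfonyl group is therefore not needed for growth inhibition in the low micromolar region of this series, since compound 4 still gives 9600 nM without it. The large penalty seen with benzoyl in the earlier steps (a 75-fold higher number from compound 1 to compound 2 (1.87 log units; beyond the scatter)) and (a 27-fold lower number from compound 2 to compound 3 (1.43 log units; beyond the scatter)) does not carry over in full to this exchange, so benzoyl has no single effect across the compounds shown, and the 3 to 4 step is the one that goes against a large penalty.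

The compounds shown leave open whether a methylsulfonyl group, a sulfonamide or a carboxylic acid could take the place of phenylsulfonyl, and how an acetyl group would behave in that position alongside the nitrile. The benzoyl steps differ in size, some large and one modest. Nothing available here explains this result.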